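Hydroxamic acid to 2-aminophenyl amide at the chain terminus

This account rests on a few compounds, and the source may have more. Where it says the series, first, only, none or still open, it means among the compounds named here.

Measured so far in a functional assay on U-937 cells (Homo sapiens) for antiproliferative activity, read by MTT assay, with a stated time of 72 h; a lower number here means a stronger inhibitor, a higher number a weaker inhibitor:
compound 1 `Cc1ccc(-c2noc(CCCCCCC(=O)NO)n2)cc1` gives 1360 nM
compound 2 `O=C(CCCCCCc1nc(-c2ccc(C(F)(F)F)cc2)no1)NO` gives 2870 nM
compound 3 `O=C(CCCCCCc1nc(-c2ccc(F)cc2)no1)NO` gives 1930 nM

Compound 2 carries the highest number of the three. Its step from compound 1 is a 2.1-fold higher number from compound 1 to compound 2 (0.32 log units; beyond the scatter), while the step between compound 2 and compound 3 is a 1.5-fold lower number from compound 2 to compound 3 (0.17 log units; within the scatter), and the step from compound 1 to compound 3 is a 1.4-fold higher number from compound 1 to compound 3 (0.15 log units; within the scatter); only compound 1 is clearly separated from compound 2.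

Compound 4 `Nc1ccccc1NC(=O)CCCCCCc1nc(-c2ccc(C(F)(F)F)cc2)no1` keeps the aromatic trifluoromethyl of compound 2 and differs from it by 2-aminophenyl in place of hydroxy on an amide-type nitrogen. None of the three measured steps touches this position: all three concern only the substituent on the aromatic carbon, and they stay modest. The change into compound 4 is therefore uncovered by anything measured here, and the expectation rests on the size of the change alone, which is larger than any of the three measured ones. A shift towards a higher number is expected, held loosely, with a wide range. For compound 4 the expected value in this assay is 7000 nM, from 2000 nM to 25000 nM, which as a step means an expected 2.4-fold higher number from compound 2 to compound 4 (0.39 log units; beyond the scatter).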

Compound 4, half-maximal inhibitory concentration: 5280 nM
Compound 4: middle estimate off by 1.3-fold (0.12 log units), on the high side; the range from low to high includes it.
By their numbers in this assay, from the lowest: compounds 1, 3, 2 and 4 (each within the scatter of the next, the first and the last beyond it).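

In this assay, the one change shown at the amide-type nitrogen stays within the scatter (a 1.8-fold higher number from compound 2 to compound 4 (0.26 log units; within the scatter)), even though 2-aminophenyl brings a six-membered aromatic ring of carbon only where hydroxy stood. With the aromatic trifluoromethyl held constant, this single pair shows that the hydroxycarbamoyl terminus is not required for a read-out in this range, as the (2-aminophenyl)carbamoyl terminus of compound 4 gives one within the scatter of compound 2. No measurement available here accounts for the similarity of the two termini.

Going by these compounds, it remains open whether the same holds for the (2-aminophenyl)carbamoyl terminus on the cores of compound 1 and compound 3, which carry methyl and fluoro. Also open, on these data alone, is how a carboxylic acid or an unsubstituted phenyl on that nitrogen would read, and with it whether the amino group of 2-aminophenyl matters.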